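A few compounds are considered here, and "the series" means these few. Any claim that something is new, unique, unknown or untested is made for them only; others in the source may bear on it.

Measured in a functional assay on A549 cells (Homo sapiens) for antiproliferative activity, read by MTT assay, with a stated time of 72 h; on this read-out higher numbers stand for weaker inhibition and lower numbers for stronger inhibition:
Compound 1 `COc1ccc(-c2noc(CCCCCCC(=O)NO)n2)cc1`: 13500 nM
Compound 2 `Nc1ccccc1NC(=O)CCCCCCc1nc(-c2ccccc2)no1`: 23900 nM
Compound 3 `COc1ccc(-c2noc(CCCCCCC(=O)C(F)(F)F)n2)cc1`: 35900 nM

Compound 3 stands level with compound 2, since their two values lie within the scatter of each other. Within the data shown here, only compound 1 is clearly apart from it, as the one measured step between the compounds shows: a 2.7-fold higher number from compound 1 to compound 3 (0.42 log units; beyond the scatter). This step is modest, and it concerns trifluoromethyl in place of hydroxyamino on a carbonyl carbon, not the aromatic ring.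

Compound 4 `O=C(CCCCCCc1nc(-c2ccc([N+](=O)[O-])cc2)no1)C(F)(F)F` keeps the trifluoromethyl of compound 3 and changes the aromatic ring instead: nitro in place of methoxy on an aromatic carbon, para to a large group (nitro in place of methoxy on an aromatic carbon). Among the measured compounds shown here, no measured pair isolates a change at this place. Compound 2 carries neither group, but it also differs at the carbonyl end, so it cannot separate the effect of the swap. The three values nevertheless sit close together despite these differences, so no large move in this assay is expected, and no direction can be favoured.

The expected outcome is no change beyond the scatter, and the estimated step is a 1.1-fold lower number from compound 3 to compound 4 (0.05 log units; within the scatter). The estimate for compound 4 is 32000 nM, with an expected range from 13000 nM to 80000 nM.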

Compound 4, half-maximal inhibitory concentration: > 100000 nM
Compound 4 ended at the assay's limit; the forecaster's own chance of this, stated with the estimate: 10%; at least 3.1-fold (0.49 log units) between middle value and limit.
By their numbers in this assay, from the lowest: compounds 1, 2 and 3 (each within the scatter of the next, the first and the last beyond it). At a limit, above all of these: compound 4.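

In this assay, the change from methoxy to nitro on an aromatic carbon, para to a large group, with the trifluoromethyl carbonyl end held the same, gives an at least 2.7-fold higher number from compound 3 to compound 4 (0.44 log units; beyond the scatter). Compound 4 stands at a limit of the assay, which is not a number: the limit of > 100000 nM in this assay, at which 1 of the 4 values shown sits. Among these compounds, the earlier compounds held no measured pair at this place on the ring, so this pair is the first to show that the read-out responds to a change there, and that the response is a move toward weaker inhibition whose full size cannot be read.

The compounds shown leave open whether this step follows from the arrival of nitro or from the departure of methoxy, and whether an amine, a fluorine or a plain hydrogen at the same ring position would stay level with compound 3 or move toward the limit of compound 4. They also leave open whether the same swap would carry over to the hydroxyamino carbonyl end of compound 1, or to a longer chain, as this evidence rests on a single pair.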